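A few compounds are considered here, and "the series" means these few. Any claim that something is new, unique, unknown or untested is made for them only; others in the source may bear on it.

Measured so far in an ADME assay on a cell-free system (plasma, Homo sapiens) for metabolic stability, with Plasma (Rattus norvegicus) as the target, read by HPLC, at pH 7.4; on this read-out lower numbers stand for a shorter-lived compound and higher numbers for a longer-lived compound:

Compound 1, `CC(=O)Oc1ccccc1C(=O)O[C@H]1CO[C@H]2[C@@H]1OC[C@H]2OC(=O)C1CC1`: 0.015 h
Compound 2, `CC(=O)Oc1ccccc1C(=O)O[C@H]1CO[C@H]2[C@@H]1OC[C@H]2OC(=O)c1ccc(C#N)cc1`: 0.068 h
Compound 3, `CC(=O)Oc1ccccc1C(=O)O[C@H]1CO[C@H]2[C@@H]1OC[C@H]2OC(=O)c1cnoc1C`: 0.001 h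

Compound 1 holds the second highest half-life of the three: compound 2 is above it by a 4.5-fold higher number from compound 1 to compound 2 (0.66 log units; beyond the scatter), and compound 3 lies below it by a 15-fold lower number from compound 1 to compound 3 (1.18 log units; beyond the scatter), both beyond the scatter. Compound 4, `CC(=O)Oc1ccccc1C(=O)O[C@H]1CO[C@H]2[C@@H]1OC[C@H]2OC(=O)CO[N+](=O)[O-]`, differs from compound 1 in one place: (nitrooxy)methyl in place of cyclopropyl on a carbonyl carbon. Neither measured step involves this group, so the direction can only be read loosely; the two neighbours of compound 1 show that swapping the acyl group moves the half-life in either direction by a modest to large amount. For compound 4 a shorter half-life than compound 1 is expected, a step of a 2.1-fold lower number from compound 1 to compound 4 (0.33 log units; beyond the scatter), with an estimate of 0.007 h ranging from 0.002 h to 0.025 h.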

Compound 4, half-life: 0.015 h
Estimate against measurement, compound 4: 2.1-fold (0.33 log units) below, within the range that was stated.
By their numbers in this assay, from the lowest: compound 3; then compounds 1 and 4 (each within the scatter of the next); then compound 2.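

In this assay the swap of cyclopropyl for (nitrooxy)methyl on a carbonyl carbon gives no change at the digits printed from compound 1 to compound 4 (within the scatter), so an acyl group with no ring can stand level with the three-membered ring here. The open group also keeps the wide gaps seen with the ring-bearing groups: a 15-fold higher number from compound 3 to compound 4 (1.18 log units; beyond the scatter) and a 4.5-fold lower number from compound 2 to compound 4 (0.66 log units; beyond the scatter). Nothing shown accounts for these results. On these data alone, whether a longer chain ending in nitrooxy, or an amine or a carboxylic acid on the chain, would hold the half-life at this level remains open.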